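The source may report more compounds than this note shows. Statements on the series, on what has been measured and on what is new or still open speak of the compounds shown alone.

Measured compounds:
compound 1 `CCCn1c(=O)[nH]c2nc(-c3ccc(S(=O)(=O)N4CCN(c5ccccc5Cl)CC4)cc3)[nH]c2c1=O` — 0.403 nM
compound 2 `CCCn1c(=O)[nH]c2nc(-c3ccc(S(=O)(=O)N4CCN(c5ccccc5C)CC4)cc3)[nH]c2c1=O` — 0.432 nM
compound 3 `CCCn1c(=O)[nH]c2nc(-c3ccc(S(=O)(=O)N4CCN(Cc5cccc(C)c5)CC4)cc3)[nH]c2c1=O` — 0.397 nM

In an assay on CHO cells for displacement of a labelled ligand from adenosine receptor A2b (Homo sapiens), read by scintillation counting, with a stated time of 75 min, in the presence of a further agent that is not named here (on this read-out lower numbers stand for stronger inhibition and higher numbers for weaker inhibition), compound 3 gives 0.397 nM. Its neighbours sit alongside it: a 1.0-fold lower number from compound 1 to compound 3 (0.01 log units; within the scatter) and a 1.1-fold lower number from compound 2 to compound 3 (0.04 log units; within the scatter), so the three numbers cannot be told apart. Compound 4 `CCCn1c(=O)[nH]c2nc(-c3ccc(S(=O)(=O)N4CCN(c5ccc(C)cc5)CC4)cc3)[nH]c2c1=O` is not yet measured. Compared with compound 3 the change is 4-methylphenyl in place of 3-methylbenzyl on an amine nitrogen in a ring. Among the compounds with values here, two measured steps touch the same amine nitrogen in a ring: a 1.0-fold lower number from compound 1 to compound 3 (0.01 log units; within the scatter) and a 1.1-fold lower number from compound 2 to compound 3 (0.04 log units; within the scatter), both exchanging an aryl group for 3-methylbenzyl without effect beyond the scatter. The third, a 1.1-fold higher number from compound 1 to compound 2 (0.03 log units; within the scatter), changes only the substituent on an aromatic carbon and is likewise flat. Returning an aryl group, here 4-methylphenyl, to that nitrogen is therefore expected to leave the number about where compound 3 stands, with no step beyond the scatter in either direction; the expected step is a 1.0-fold higher number from compound 3 to compound 4 (0.01 log units; within the scatter). Compound 4 is estimated at 0.41 nM in this assay, with a range from 0.2 nM to 0.85 nM.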

Compound 4, inhibition constant: 0.706 nM
Compound 4: the middle estimate sits 1.7-fold (0.24 log units) below what was measured, within the range that was stated.
By their numbers in this assay, from the lowest: compounds 3, 1, 2 and 4 (each within the scatter of the next).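

In this assay, the 4-methylphenyl group on the amine nitrogen in the ring stays within the scatter of all three earlier groups: a 1.8-fold higher number from compound 3 to compound 4 (0.25 log units; within the scatter), a 1.6-fold higher number from compound 2 to compound 4 (0.21 log units; within the scatter) and a 1.8-fold higher number from compound 1 to compound 4 (0.24 log units; within the scatter). Within the data shown here, the step from compound 2 adds what the earlier compounds did not show, that 2-methylphenyl and 4-methylphenyl on this nitrogen cannot be told apart, so this position has now accepted 2-chlorophenyl, 2-methylphenyl, 4-methylphenyl and 3-methylbenzyl with no step beyond the scatter. No measured evidence is available to explain the result.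

On these data alone, all four groups are uncharged and carry a carbon-only aromatic ring, so it remains open whether a carboxylic acid or an amine on that ring would leave the number within the scatter. As far as these compounds go, a longer chain, such as 2-phenylethyl, on the same nitrogen is equally open.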